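The source may hold more compounds than are shown below. What is called first, only, known or untested is meant among the compounds shown, and "the series" means these compounds.

Working notes on the series. Compound 1 `COc1cc2c(Oc3ccc(NC(=O)c4nnn(-c5ccccc5C)c4C)cc3F)ccnc2cc1OCCCN1CCCCC1` and compound 3 `COc1cc2c(Oc3ccc(NC(=O)c4nnn(-c5ccccc5C)c4C)cc3F)ccnc2cc1OCCCN1CCC(C)CC1` share one core and differ only by methyl in place of hydrogen on a saturated ring carbon. In a functional assay on A549 cells (Homo sapiens) for cytotoxicity, read by MTT assay, with a stated time of 72 h (a higher number here means a weaker inhibitor, a lower number a stronger inhibitor), compound 1 gives 330 nM, and compound 3 gives 360 nM; the step of a 1.1-fold higher number from compound 1 to compound 3 (0.04 log units; within the scatter) lies within the scatter, so the two numbers are read as equivalent. Compound 2 `COc1cc2c(Oc3ccc(NC(=O)c4nnn(-c5ccc(F)cc5)c4C(F)(F)F)cc3F)ccnc2cc1OCCCN1CCCCC1` carries a different core; the difference between the two cores is not broken down here. In this assay compound 2 gives 110 nM, the lowest of the three numbers, with compound 1 and compound 3 each beyond the scatter above it.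

Compound 4 `COc1cc2c(Oc3ccc(NC(=O)c4nnn(-c5ccc(F)cc5)c4C(F)(F)F)cc3F)ccnc2cc1OCCCN1CCC(C)CC1` is not yet measured. It stands to compound 2 as compound 3 stands to compound 1, by methyl in place of hydrogen on a saturated ring carbon, at the same place on the same ring as before. The earlier instance of this change, a 1.1-fold higher number from compound 1 to compound 3 (0.04 log units; within the scatter), stayed within the scatter. On that single precedent the corresponding step is expected at a 1.1-fold higher number from compound 2 to compound 4 (0.04 log units; within the scatter), with the caveat that one prior step is thin ground. Compound 4 is accordingly estimated at 120 nM, with a range from 60 nM to 250 nM.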

Compound 4, half-maximal inhibitory concentration: 120 nM
For compound 4 middle estimate and measured number coincide at the digits printed; the measured number falls inside the stated range.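

In this assay, the change from piperidin-1-yl to 4-methylpiperidin-1-yl gives a 1.1-fold higher number from compound 2 to compound 4 (0.04 log units; within the scatter), and the two instances of this change agree: the same change on two cores in this assay, a 1.1-fold higher number (0.04 log units; within the scatter) from compound 1 to compound 3 and a 1.1-fold higher number (0.04 log units; within the scatter) from compound 2 to compound 4, 1.0-fold (0.00 log units) apart, within the scatter of two such steps. Within these four compounds, then, the methyl carries from the core of compound 1 to the core of compound 2 with no step beyond the scatter on either core, and the gap between the two steps also stays within the scatter. This does not show that the change is without effect on every core in the series, since the evidence is two cores, one place on the ring and one cell assay, and it does not break down the difference between the two cores.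

The compounds shown leave open what an ethyl group, a hydroxyl group or a carboxylic acid would do in place of the methyl at the same place on the ring. On these data alone, how the methyl step reads on a third core also remains open.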